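Aryl esters on a shared core: methyl to methoxy

The source may report more compounds than this note shows. Statements on the series, on what has been measured and on what is new or still open speak of the compounds shown alone.

Measured so far:
compound 1, `COc1cccc(C(=O)Oc2cc3c(cc2C)[C@@H](C(C)C)CC=C3C)c1`, 16.3%
compound 2, `CC1=CC[C@H](C(C)C)c2cc(C)c(OC(=O)c3ccc(C)cc3)cc21`, 49.6%

Among the compounds with values here, in a functional assay on PC-3 cells (Homo sapiens) for antiproliferative activity, read by sulforhodamine B assay, with a stated time of 48 h, tested at 50 uM (a higher number here means more inhibition at the concentration tested (going by the name of the read-out), a lower number less inhibition), compound 2 stands highest of the two numbers; the nearest is compound 1, and the one step between them, a number 33.3 percentage points higher from compound 1 to compound 2 (beyond the scatter), is large. Compound 3, `COc1ccc(C(=O)Oc2cc3c(cc2C)[C@@H](C(C)C)CC=C3C)cc1`, is not yet measured. Relative to compound 2 the change is methoxy in place of methyl on an aromatic carbon. Within the data shown here, no measured step exchanges methyl for methoxy at the same place; the step from compound 1 to compound 2 alters both the group and its place on the ring at once, so it bears on compound 3 only loosely, showing that the ester aryl part can move the number by a large amount. A step within the scatter in either direction is therefore the most one can expect for a number 11.6 percentage points lower from compound 2 to compound 3 (beyond the scatter), with wide uncertainty. For compound 3 the estimate in this assay is 38%, with a range from 15% to 58%.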

Compound 3, a percentage reported as inhibition, at one concentration (the size of the read-out at that concentration, not a potency): 60.6%
The estimate for compound 3 lay 22.6 percentage points below the measured number; measured number outside the range, above it.
By their numbers in this assay, from the lowest: compound 1; then compound 2; then compound 3.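

In this assay, methoxy in place of methyl on the aromatic carbon para to a large group gives a modest gain, a number 11 percentage points higher from compound 2 to compound 3 (beyond the scatter), so this place accepts the extra oxygen without loss of inhibition. The second comparison, 4-methoxyphenyl in place of 3-methoxyphenyl on the carbonyl carbon, keeps the group and changes only its place, which the earlier step could not do, and it is large: a number 44.3 percentage points higher from compound 1 to compound 3 (beyond the scatter). No supporting data give a reason for either step.

Still open, as far as these compounds go, is how an amine, a carboxylic acid or a longer alkoxy chain would read at this place on the ester aryl ring. These numbers also come from a single concentration, so they give the size of the inhibition there and not a potency.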